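Swapping methoxy for chloro in compound 3

A few compounds are considered here, and "the series" means these few. Any claim that something is new, unique, unknown or untested is made for them only; others in the source may bear on it.

In a functional assay on MCF7 cells (Homo sapiens) for antiproliferative activity, read by sulforhodamine B assay, with a stated time of 48 h (on this read-out higher numbers stand for weaker inhibition and lower numbers for stronger inhibition), compound 1 `COc1cccc(OS(=O)(=O)c2ccc(N3CCN(C)C3=O)cc2)c1` gives 3000 nM. Compound 3 `CCN1CCN(c2ccc(S(=O)(=O)Oc3cccc(OC)c3)cc2)C1=O`, with one further methyl on its saturated chain, gives 14000 nM, the higher of the two actual numbers. That extra methyl accounts for a 4.7-fold higher number from compound 1 to compound 3 (0.67 log units; beyond the scatter). Compound 2 `CN1CCN(c2ccc(S(=O)(=O)Oc3ccc(Cl)cc3)cc2)C1=O` gives > 100000 nM, which is a limit of the assay and not a number.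

Compound 4 `CCN1CCN(c2ccc(S(=O)(=O)Oc3cccc(Cl)c3)cc2)C1=O` differs from compound 3 by chloro in place of methoxy on an aromatic carbon, turning 3-methoxyphenyl into 3-chlorophenyl (chloro in place of methoxy on an aromatic carbon). The closest guide is the change from 3-methoxyphenyl to 4-chlorophenyl, which gave an at least 33-fold higher number from compound 1 to compound 2 (1.52 log units; beyond the scatter). That large step is only a loose guide, since its chloro group is not placed as in compound 4. The methyl step lies elsewhere in the structure and bears on this change only by setting the starting value. A higher number is therefore expected in this assay, though probably a smaller rise than the large one. The expected change is a 2.5-fold higher number from compound 3 to compound 4 (0.40 log units; beyond the scatter). For compound 4 the estimated value is 35000 nM, with an expected range from 10000 nM to 100000 nM.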

Compound 4, half-maximal inhibitory concentration: 5400 nM
For compound 4 the middle estimate is 6.5-fold (0.81 log units) above the measured one; measured number below the stated range.
By their numbers in this assay, from the lowest: compounds 1 and 4 (each within the scatter of the next); then compound 3. At a limit, above all of these: compound 2.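

In this assay, chloro can stand in for methoxy on this ring carbon without any loss, and the swap gives a 2.6-fold lower number from compound 3 to compound 4 (0.41 log units; beyond the scatter). For the compounds shown here, the only earlier chloro compound carried a 4-chlorophenyl group, so its step, an at least 33-fold higher number from compound 1 to compound 2 (1.52 log units; beyond the scatter), could have suggested that chloro itself was harmful, whereas the 3-chlorophenyl group of compound 4 shows that chloro at this place is not. Compound 2 still gives only a limit and not a number, so the full size of its step stays unknown: the limit of > 100000 nM in this assay, at which 1 of the 4 values shown sits.

From the compounds shown here alone, whether chloro would also lower the number on the core of compound 1 remains open. So does whether an amine, a carboxylic acid or a fluoro group at this place on the ring would do as well as chloro.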